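Trimethoxyphenyl on the Ring: Expected Growth Inhibition of Compound 4

The source may report more compounds than this note shows. Statements on the series, on what has been measured and on what is new or still open speak of the compounds shown alone.

Of the compounds shown here, three sharing one core have been measured in a functional assay on SK-MEL-2 cells (Homo sapiens) for inhibition; a higher number here means a weaker inhibitor of growth, a lower number a stronger inhibitor of growth. Compound 2 `COc1ccc(-c2cn(-c3cccc(C(=O)/C=C/c4cc(OC)c(OC)c(OC)c4)c3)c(=O)[nH]2)cc1` gives 2630 nM, the lowest of the three numbers. Compound 1 `COc1cc(/C=C/C(=O)c2cccc(-n3cc(-c4ccc(Cl)cc4)[nH]c3=O)c2)ccc1O` gives 3660 nM, and these two values lie within the scatter of each other. Compound 3 `COc1ccc(-c2cn(-c3cccc(C(=O)/C=C/c4ccc(O)c(OC)c4)c3)c(=O)[nH]2)cc1` gives 5540 nM; the step of a 2.1-fold higher number from compound 2 to compound 3 (0.32 log units; beyond the scatter) is modest but beyond the scatter.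

Compound 4 `COc1cc(/C=C/C(=O)c2cccc(-n3cc(-c4cc(OC)c(OC)c(OC)c4)[nH]c3=O)c2)cc(OC)c1OC` has not yet been measured. It differs from compound 2 in one place: 3,4,5-trimethoxyphenyl in place of 4-methoxyphenyl on an aromatic carbon.

For the measured compounds named here, no measured pair shows exactly this change. The closest is a 1.5-fold higher number from compound 1 to compound 3 (0.18 log units; within the scatter), which also varied the aryl group in that part of the molecule and moved the number only within the scatter. The other step, a 2.1-fold higher number from compound 2 to compound 3 (0.32 log units; beyond the scatter), concerns a different place, where the 3,4,5-trimethoxyphenyl was favored over the 4-hydroxy-3-methoxyphenyl. Together these suggest that compound 4 is expected to show only a small shift in this assay, if any, with a slight lean toward a lower number, so the estimated step of a 1.2-fold lower number from compound 2 to compound 4 (0.08 log units; within the scatter) should stay near the scatter. Compound 4 is therefore estimated at 2200 nM, with a likely range from 1100 nM to 4500 nM.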

Compound 4, concentration for 50% growth inhibition: 3020 nM
Compound 4: middle estimate off by 1.4-fold (0.14 log units), on the low side; low and high end bracket the measured number.
By their numbers in this assay, from the lowest: compounds 2, 4, 1 and 3 (each within the scatter of the next, the first and the last beyond it).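

In this assay, for the compounds shown here, the result gives the first direct reading of a change confined to the aryl group on the aromatic carbon of the five-membered ring, with the rest of compound 2 held fixed: a 1.1-fold higher number from compound 2 to compound 4 (0.06 log units; within the scatter) when 3,4,5-trimethoxyphenyl, with 12 heavy atoms and 3 hydrogen-bond acceptors, takes the place of 4-methoxyphenyl, with 8 heavy atoms and 1 acceptor. The earlier step at this place, a 1.5-fold higher number from compound 1 to compound 3 (0.18 log units; within the scatter), was a swap of chloro for methoxy on the aryl group and carried the 4-hydroxy-3-methoxyphenyl at the far end of the molecule, whereas the new step carries the 3,4,5-trimethoxyphenyl there. Both steps at this place therefore stay within the scatter, on two different far-end groups, so among these compounds the assay does not separate the aryl groups tried here, while the one step beyond the scatter lies at the other end of the molecule.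

From the compounds shown here alone, whether an amine, a carboxylic acid or a longer chain on this aryl group would move the number beyond the scatter remains open. The data shown contain nothing that explains this result.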